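A Methyl Added to the Aromatic Ring of Compound 1

This account rests on a few compounds, and the source may have more. Where it says the series, first, only, none or still open, it means among the compounds named here.

compound 1, `C=CCOc1c(C)c(C)c2c(c1C)CCC(C)(COc1ccc(/C=C3\SC(=O)NC3=O)cc1)O2`: 45%
compound 2, `C=CCOc1c(C)c(C)c2c(c1C)CCC(C)(COc1cccc(/C=C3\SC(=O)NC3=O)c1)O2`: 84%

Of the compounds shown here, two have been measured in a functional assay on MCF7 cells (Homo sapiens), tested at 2.5 uM; a higher number here means a weaker effect of the compound at the concentration tested, a lower number a stronger effect. Compound 1 gives 45%, the lowest of the two numbers, and compound 2 gives 84%, a gap beyond the usual scatter. Compound 3, `C=CCOc1c(C)c(C)c2c(c1C)CCC(C)(COc1ccc(/C=C3\SC(=O)NC3=O)cc1C)O2`, has not yet been measured. It differs from compound 1 in one place: methyl in place of hydrogen on an aromatic carbon. The change sits on an aromatic carbon of a six-membered aromatic ring of carbon only, ortho to a large group and meta to a group of 8 heavy atoms. Among the measured compounds shown here, no step between two measured compounds involves such a change, so the measured pair gives no guide to its size. With nothing to lean on, the step from compound 1 to compound 3 is estimated at a number 5 percentage points higher from compound 1 to compound 3 (within the scatter), within the scatter. Compound 3 is therefore expected to give about 50%, in a range from 25% to 78%.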

Compound 3, a percentage reported as activity, at one concentration (the size of the read-out at that concentration, not a potency): 84%
Compound 3: the middle estimate sits 34 percentage points below what was measured, and the stated range ends below it.
By their numbers in this assay, from the lowest: compound 1; then compounds 2 and 3 (each within the scatter of the next).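

In this assay, this position proves sensitive to a very small change: methyl in place of hydrogen on an aromatic carbon, ortho to a large group and meta to a group of 8 heavy atoms, gives a large step (a number 39 percentage points higher from compound 1 to compound 3 (beyond the scatter)). The change adds only 1 heavy atom and no hydrogen-bond donors or acceptors, yet the effect of compound 1 at the concentration tested is clearly weakened in compound 3. Among the compounds shown here, the earlier compounds offered no step at this position, so this is the first sign that substitution on this aromatic carbon matters. Nothing in the data shown explains why the step is so large.

As far as these compounds go, whether the weakening is specific to methyl or would also follow a fluorine, a chlorine or an ethyl group on this carbon remains open. From the compounds shown here alone, it is also open how a methoxy group or an amine at the same place would read out.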